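A few compounds are considered here, and "the series" means these few. Any claim that something is new, unique, unknown or untested is made for them only; others in the source may bear on it.

Series notes. Compound 1 `O=C1N=C(N2N=C(c3ccccc3)CC2c2ccccc2O)S/C1=C1/C(=O)Nc2ccccc21` is the parent; compound 2 `O=C1N=C(N2N=C(c3ccccc3)CC2c2ccccc2O)S/C1=C1/C(=O)Nc2ccc(Br)cc21` carries bromo in place of hydrogen on an aromatic carbon. In a functional assay on cells (Cancer cell lines, Homo sapiens) for cytotoxicity, read by sulforhodamine B assay, with a stated time of 48 h (on this read-out higher numbers stand for weaker inhibition of growth and lower numbers for stronger inhibition of growth), compound 1 gives 4350 nM and compound 2 gives 930 nM, so the bromo step gives a 4.7-fold lower number from compound 1 to compound 2 (0.67 log units; beyond the scatter). Compound 3 `COc1ccc(C2=NN(C3=NC(=O)/C(=C4\C(=O)Nc5ccccc54)S3)C(c3ccc(Cl)cc3)C2)cc1` has a different core; the difference between the two cores is not broken down here. In this assay compound 3 gives 100000 nM, the highest number of the three measured. Compound 4 `COc1ccc(C2=NN(C3=NC(=O)/C(=C4\C(=O)Nc5ccc(Br)cc54)S3)C(c3ccc(Cl)cc3)C2)cc1` repeats the same change on the second core, (bromo in place of hydrogen on an aromatic carbon), awaiting measurement in this assay. For the measured compounds named here, by analogy with compound 2, whose step from compound 1 is a 4.7-fold lower number from compound 1 to compound 2 (0.67 log units; beyond the scatter), compound 4 is expected to show a step of a 3.3-fold lower number from compound 3 to compound 4 (0.52 log units; beyond the scatter), tempered because compound 3 sits at 100000 nM, the highest number of the three measured, and the same change has been seen on only one core. Compound 4 is thus estimated at 30000 nM, with a range from 8000 nM to 100000 nM.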

Compound 4, concentration for total growth inhibition: 1010 nM
Estimate against measurement, compound 4: 30-fold (1.47 log units) above; measured number below the stated range.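

In this assay the bromo change lowers the number again, with a 99-fold lower number from compound 3 to compound 4 (2.00 log units; beyond the scatter), so the direction carries over to the second core but the size does not: the same change on two cores in this assay, a 4.7-fold lower number (0.67 log units; beyond the scatter) from compound 1 to compound 2 and a 99-fold lower number (2.00 log units; beyond the scatter) from compound 3 to compound 4, 21-fold (1.33 log units) apart, beyond the scatter of two such steps

The step therefore cannot be carried from one core to another as a fixed amount in this series. Two pairs do not show which of the differences between the cores goes with the larger step, nor whether the direction would hold on a third core.

Still open, on these data alone, is whether fluoro or an amine on the same aromatic carbon would follow the bromo step on either core.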